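Swapping the urea aryl group on compound 1

This account rests on a few compounds, and the source may have more. Where it says the series, first, only, none or still open, it means among the compounds named here.

Measured compounds:
compound 1 `O=C(Nc1cccc(-n2cc(-c3ccncc3)c(-c3ccc(Cl)c(O)c3)n2)c1)Nc1cccc(C(F)(F)F)c1`: 3590 nM
compound 2 `COc1cc(-c2nn(-c3cccc(NC(=O)Nc4cc(C(F)(F)F)cc(C(F)(F)F)c4)c3)cc2-c2ccncc2)ccc1Cl`: 664 nM
compound 3 `COc1cc(-c2nn(-c3cccc(NC(=O)c4cccc(C(F)(F)F)c4)c3)cc2-c2ccncc2)ccc1Cl`: 1240 nM

Of the compounds shown here, three sharing one core have been tested in a functional assay on MDA-MB-231 cells (Homo sapiens) for inhibition, read by sulforhodamine B assay, with a stated time of 48 h; on this read-out higher numbers stand for weaker inhibition of growth and lower numbers for stronger inhibition of growth. In this assay compound 1 gives 3590 nM, the highest of the three numbers, which means the weakest growth inhibition here. The nearest to it is compound 3 with 1240 nM, a lower number and a gap beyond the usual scatter; furthest is compound 2 with 664 nM, lower still and also beyond the scatter. Each of these two differs from compound 1 in more than one place, so no single change can be read off from them.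

Compound 4 `O=C(Nc1cccc(-n2cc(-c3ccncc3)c(-c3ccc(Cl)c(O)c3)n2)c1)Nc1ccc(Cl)c(Cl)c1` has not been measured. It differs from compound 1 in one place: 3,4-dichlorophenyl in place of 3-(trifluoromethyl)phenyl on an amide-type nitrogen. Going by the values given here, nothing among the measured compounds isolates this kind of swap, so the size of the step is unknown. The expectation is a modest step, if any, toward stronger growth inhibition, so that the change from compound 1 to compound 4 in this assay is estimated as a 1.5-fold lower number from compound 1 to compound 4 (0.17 log units; within the scatter). For compound 4 the expected value in this assay is 2400 nM, with a likely range from 900 nM to 6500 nM.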

Compound 4, concentration for 50% growth inhibition: 1180 nM
Estimate against measurement, compound 4: 2.0-fold (0.31 log units) above; low and high end bracket the measured number.
By their numbers in this assay, from the lowest: compounds 2, 4 and 3 (each within the scatter of the next); then compound 1.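

In this assay, going by these compounds alone, putting 3,4-dichlorophenyl in place of 3-(trifluoromethyl)phenyl on the amide-type nitrogen gives a 3.0-fold lower number from compound 1 to compound 4 (0.48 log units; beyond the scatter), the first step in this set that changes only one place. It shows that the aryl group at this position alone can move the number by more than the usual scatter, here toward stronger inhibition of growth, while the rest of compound 1 stays unchanged. The two groups have the same counts of one six-membered aromatic ring of carbon only, 0 hydrogen-bond donors and 0 hydrogen-bond acceptors, and neither carries a net charge, so these counts do not separate them, and nothing available explains the step.

On these data alone, whether a plain phenyl, a cyclohexyl ring or a phenyl carrying a dimethylamino group on this nitrogen would lower the number further or raise it remains open. As far as these compounds go, the gaps to the other compounds cannot be read as steps, as each involves more than one place, so it is also open whether this swap would give a similar step on a compound with a methoxy group in place of the hydroxyl group.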